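The source may hold more compounds than are shown below. What is called first, only, known or untested is meant among the compounds shown, and "the series" means these compounds.

Working notes on the acylguanidine series sharing one core. Compound 1 `NC(N)=NC(=O)c1nc(Cl)c(NC2CC2)nc1N` gives "not determined" (no result reported) in an assay for inhibition of acid-sensing ion channel 3 (Homo sapiens), read by patch clamp, tested at 1 uM (on this read-out higher numbers stand for more inhibition at the one concentration tested (going by the name of the read-out) and lower numbers for less inhibition), so no number is available for it. Compound 2 `NC(N)=NC(=O)c1nc(Cl)c(NC2CCCCC2)nc1N` gives 21% in this assay. Compound 3 `NC(N)=NC(=O)c1nc(Cl)c(N2CCCC2)nc1N` gives 12% in this assay, the lower of the two numbers, though the step of a number 9 percentage points lower from compound 2 to compound 3 (within the scatter) lies within the scatter, so no ranking of compound 2 and compound 3 is drawn. Compound 4 `NC(N)=NC(=O)c1nc(Cl)c(Nc2ccccc2)nc1N` is not yet measured; its change from compound 3 is anilino in place of pyrrolidin-1-yl on an aromatic carbon. Within the data shown here, the only step bearing on it, a number 9 percentage points lower from compound 2 to compound 3 (within the scatter), also swapped the substituent at this ring carbon and stayed within the scatter. For compound 4 no move beyond the scatter is therefore expected in this assay, an expected step of a number 6 percentage points higher from compound 3 to compound 4 (within the scatter). Compound 4 is estimated at 18%, range 4% to 40%.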

Compound 4, a percentage reported as inhibition, at one concentration (the size of the read-out at that concentration, not a potency): 44%
For compound 4 the middle estimate is 26 percentage points below the measured one, and the stated range ends below it.
By their numbers in this assay, from the lowest: compounds 3 and 2 (each within the scatter of the next); then compound 4.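

In this assay the group on this ring carbon now shifts the read-out beyond the scatter: anilino in place of pyrrolidin-1-yl gives a number 32 percentage points higher from compound 3 to compound 4 (beyond the scatter) in the step shown. Phenyl in place of cyclohexyl on the nitrogen gives a number 23 percentage points higher from compound 2 to compound 4 (beyond the scatter) as well, so the aromatic ring separates compound 4 even from the other compound with a ring on an amino nitrogen. No evidence here explains either step.

Going by these compounds, whether a methoxy group or a carboxylic acid on the phenyl ring keeps this level remains open. So does the outcome for benzylamino in place of anilino.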